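Urea aryl exchange on the shared core: compound 3

This account rests on a few compounds, and the source may have more. Where it says the series, first, only, none or still open, it means among the compounds named here.

Compound 2 `CC(C)(C)c1ccc(NC(=O)Nc2cccc(CNc3ncnc4ccccc34)c2)cc1` stands at 17900 nM in a functional assay on A549 cells (Homo sapiens) for antiproliferative activity, read by MTT assay; a higher number here means a weaker inhibitor, a lower number a stronger inhibitor. Compound 1 `Cc1cccc(NC(=O)Nc2cccc(CNc3ncnc4ccccc34)c2)c1` stands at 30200 nM, and the step of a 1.7-fold lower number from compound 1 to compound 2 (0.23 log units; within the scatter) lies within the scatter, so the two numbers are not separated. Compound 3 `O=C(Nc1cccc(CNc2ncnc3ccccc23)c1)Nc1ccccc1Cl` is not yet measured; it differs from compound 2 by 2-chlorophenyl in place of 4-(tert-butyl)phenyl on an amide-type nitrogen. Among the measured compounds shown here, the one step that bears on it is the exchange of one aryl group on the same amide-type nitrogen between compound 1 and compound 2, which stayed within the scatter, so no step beyond the scatter is expected here. Compound 3 is therefore estimated at 25000 nM, with a range of 8000 nM to 80000 nM. The expected step is a 1.4-fold higher number from compound 2 to compound 3 (0.15 log units; within the scatter).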

Compound 3, half-maximal inhibitory concentration: 18000 nM
Compound 3: the middle estimate sits 1.4-fold (0.14 log units) above what was measured; measured number inside the range.
By their numbers in this assay, from the lowest: compounds 2, 3 and 1 (each within the scatter of the next).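

In this assay, a third aryl group on the amide-type nitrogen again gives no separation: a 1.0-fold higher number from compound 2 to compound 3 (0.00 log units; within the scatter), and a 1.7-fold lower number from compound 1 to compound 3 (0.22 log units; within the scatter). The exchange now covers 2-chlorophenyl as well as 4-(tert-butyl)phenyl and 3-methylphenyl, so a chlorine-bearing ring joins the two carbon-only substituted rings with every step among the three compounds within the scatter. Nothing available bears on the reason for this result. Open, going by these compounds, is whether any group on this nitrogen gives a step beyond the scatter. A phenyl carrying a carboxylic acid or an amine would test that.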